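Working notes: methyl in place of bromo

A few compounds are considered here, and "the series" means these few. Any claim that something is new, unique, unknown or untested is made for them only; others in the source may bear on it.

Values from a functional assay on DU-145 cells (Homo sapiens) for inhibition, read by trypan blue exclusion, with a stated time of 96 h (on this read-out lower numbers stand for stronger inhibition of growth and higher numbers for weaker inhibition of growth), for the series
- compound 1 `Cc1ccc(S(=O)(=O)/C(=C/c2ccc(O)c([N+](=O)[O-])c2)C(=O)c2ccc(Cl)cc2)cc1`: 25000 nM
- compound 2 `Cc1ccc(S(=O)(=O)/C(=C/c2ccc(N(C)C)cc2)C(=O)c2ccc(Cl)cc2)cc1`: > 100000 nM
- compound 3 `COc1ccc(/C=C(\C(=O)c2ccc(Cl)cc2)S(=O)(=O)c2ccc(Br)cc2)cc1O`: 10000 nM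

Compound 2 gives > 100000 nM as a limit of the assay and not a number. Compound 3 holds the lower of the two actual numbers, and compound 1 reads higher at 25000 nM by a gap beyond the scatter. Compound 4 `COc1ccc(/C=C(\C(=O)c2ccc(Cl)cc2)S(=O)(=O)c2ccc(C)cc2)cc1O` carries methyl in place of bromo on an aromatic carbon, para to a large group (methyl in place of bromo on an aromatic carbon). Among the measured compounds shown here, the only measured step, an at least 4.0-fold higher number from compound 1 to compound 2 (0.60 log units; beyond the scatter), changes another place, so no measured step bears on this change and no step beyond the scatter is expected in this assay. The expectation therefore rests on compound 3 at 10000 nM alone. The expected step is a 1.2-fold higher number from compound 3 to compound 4 (0.08 log units; within the scatter). Compound 4 is estimated at 12000 nM, with an expected range from 4000 nM to 40000 nM.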

Compound 4, concentration for 50% growth inhibition: 1000 nM
Estimate against measurement, compound 4: 12-fold (1.08 log units) above, and the stated range ends above it.
By their numbers in this assay, from the lowest: compound 4; then compound 3; then compound 1. At a limit, above all of these: compound 2.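

In this assay, among the compounds shown here, this aromatic carbon, para to a large group, proves sensitive to the change: methyl in place of bromo gives a 10-fold lower number from compound 3 to compound 4 (1.00 log units; beyond the scatter), the first measured step at this place. With methyl held in place, 3-hydroxy-4-methoxyphenyl on the double-bonded chain carbon gives a 25-fold lower number from compound 1 to compound 4 (1.40 log units; beyond the scatter) and an at least 100-fold lower number from compound 2 to compound 4 (2.00 log units; beyond the scatter). The value of compound 2 is a limit: the limit of > 100000 nM in this assay, at which 1 of the 4 values shown sits.

The compounds shown leave open how an ethyl, a methoxy or an amine would read at this carbon, and whether methyl in place of bromo gives a similar step with any other group on the chain.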